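Moving on from the 2-methoxyphenyl of compound 2

The compounds below may be only part of what the source reports. "The series", "measured", "known", "first", "only" and "open" are said of these compounds alone.

Among the compounds with values here, in a functional assay on K562 cells (Homo sapiens) for antiproliferative activity, with a stated time of 72 h (a lower number here means a stronger inhibitor, a higher number a weaker inhibitor), compound 2 `COc1ccccc1CNc1ncnc2c1ncn2[C@@H]1O[C@H](CO)[C@@H](O)[C@H]1O` gives 89000 nM and holds the higher of the two numbers so far, with compound 1 `OC[C@H]1O[C@@H](n2cnc3c(NCc4cccc(F)c4)ncnc32)[C@H](O)[C@@H]1O` at 7600 nM as its only neighbour. Compound 3 `COc1cc(CNc2ncnc3c2ncn3[C@@H]2O[C@H](CO)[C@@H](O)[C@H]2O)cc(OC)c1` carries 3,5-dimethoxyphenyl in place of 2-methoxyphenyl on a saturated chain carbon bound to a nitrogen on an aromatic ring. Within the data shown here, the one measured step at this place is large, a 12-fold higher number from compound 1 to compound 2 (1.07 log units; beyond the scatter) with 2-methoxyphenyl replacing 3-fluorophenyl, so compound 3, which leaves the 2-methoxyphenyl behind, is expected to regain part of it. No 3,5-dimethoxyphenyl compound has been measured yet, so the size remains uncertain. The step expected in this assay is a 3.0-fold lower number from compound 2 to compound 3 (0.47 log units; beyond the scatter) by this estimate. For compound 3 the estimated value is 30000 nM with a range from 8000 nM to 100000 nM as expected bounds.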

Compound 3, half-maximal inhibitory concentration: > 166000 nM
Compound 3 gave a limit, no number; the forecaster's own chance of this, stated with the estimate: 10%; middle value at least 5.5-fold (0.74 log units) from the limit.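

In this assay compound 3 gives > 166000 nM, which is a limit of the assay and not a number. Leaving the 2-methoxyphenyl behind therefore won back nothing that can be seen: the reading is an at least 1.8-fold higher number from compound 2 to compound 3 (0.27 log units; that floor lies within the scatter), and since that floor lies within the scatter, the two compounds cannot be ranked. The methoxy-bearing rings both stay far from the 3-fluorophenyl, with an at least 21-fold higher number from compound 1 to compound 3 (1.33 log units; beyond the scatter).

Still open, going by these compounds, is whether the fluorine itself matters, or whether an unsubstituted phenyl or a 3-chlorophenyl at this place would match compound 1.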